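Flipping One Stereocentre in Compound 3

The source may hold more compounds than are shown below. What is called first, only, known or untested is meant among the compounds shown, and "the series" means these compounds.

Of the compounds shown here, three sharing one core have been measured in a functional assay (brain) for inhibition, with Rattus norvegicus as the target; on this read-out lower numbers stand for stronger inhibition and higher numbers for weaker inhibition. Compound 1 `Cc1c(C)c2c(c(C)c1O)CC[C@@](C)(CC(=O)O)O2` gives 17000 nM, and compound 2 `Cc1c(C)c2c(c(C)c1O)CC[C@@](C)(CC(=O)[N-][N+](C)(C)C)O2` gives 9000 nM, a step of a 1.9-fold lower number from compound 1 to compound 2 (0.28 log units; within the scatter). Compound 3 `Cc1c(C)c2c(c(C)c1O)CC[C@](C)(CC[S+](C)C)O2` gives 2000 nM, the lowest number of the three and beyond the scatter from both others. Compound 4 `Cc1c(C)c2c(c(C)c1O)CC[C@@](C)(CC[S+](C)C)O2` is its mirror partner: the two compounds have the same atoms and bonds and differ only in configuration as drawn: 1 of 1 stereo elements differ; a stereocentre at a saturated ring carbon is drawn R in compound 3 and S in compound 4. No measured pair differs only in configuration, so none of the shown steps bears directly on this change; the single step shown concerns a group on the carbonyl carbon. Such a swap may leave the number unchanged or move it well beyond the scatter in either direction. The expected change is a 2.0-fold higher number from compound 3 to compound 4 (0.30 log units; within the scatter), with wide uncertainty. Compound 4 is estimated at 4000 nM, within a range from 1000 nM to 20000 nM.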

Compound 4, half-maximal inhibitory concentration: 2000 nM
Estimate against measurement, compound 4: 2.0-fold (0.30 log units) above, within the range that was stated.
By their numbers in this assay, from the lowest: compounds 3 and 4 (each within the scatter of the next); then compounds 2 and 1 (each within the scatter of the next).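

Inverting the stereocentre at the saturated ring carbon gives no change at the digits printed from compound 3 to compound 4 (within the scatter) in this assay and so, for this sulfur-bearing chain, the drawn configuration at this carbon makes no visible difference. Among these compounds, the one structural change in this pair is the configuration: the fact that compounds 3 and 4 differ only in the configuration as drawn. The steps of a 4.5-fold lower number from compound 2 to compound 4 (0.65 log units; beyond the scatter) and an 8.5-fold lower number from compound 1 to compound 4 (0.93 log units; beyond the scatter) show that the sulfur-bearing group keeps its advantage in either configuration.

From the compounds shown here alone, it remains open whether configuration at this carbon would matter as little with an amine or a longer chain in place of this group.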